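The source may report more compounds than this note shows. Statements on the series, on what has been measured and on what is new or still open speak of the compounds shown alone.

Compounds measured in a functional assay on HL-60 cells (Homo sapiens) for antiproliferative activity, read by MTT assay, with a stated time of 48 h; a higher number here means a weaker inhibitor, a lower number a stronger inhibitor:
compound 1, `O=C(CC[C@H](NC(=O)c1cc2ccccc2cn1)C(=O)OCc1ccccc1)OCc1ccccc1`, 83.6 nM
compound 2, `CC(C)[C@H](NC(=O)c1cc2ccccc2cn1)C(=O)OCc1ccccc1`, 78.9 nM
compound 3, `NC(=O)CC[C@H](NC(=O)c1cc2ccccc2cn1)C(=O)OCc1ccccc1`, 44.5 nM

The three share one core and differ only in the side chain on the saturated chain carbon bound to an amide-type nitrogen and a carbonyl carbon, or in the group on the carbonyl carbon of that chain. Compound 2 gives the second highest of the three numbers, but none of its neighbours is separated from it by more than the scatter: a 1.1-fold lower number from compound 1 to compound 2 (0.03 log units; within the scatter), and a 1.8-fold lower number from compound 2 to compound 3 (0.25 log units; within the scatter). The remaining pair behaves the same way, with a 1.9-fold lower number from compound 1 to compound 3 (0.27 log units; within the scatter).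

Compound 4, `O=C(CNC(=O)c1cc2ccccc2cn1)OCc1ccccc1`, is the next step from compound 2. Its change is hydrogen in place of isopropyl on a saturated chain carbon bound to an amide-type nitrogen and a carbonyl carbon.

Two measured steps alter that same position, the step from compound 1 to compound 2 and the step from compound 2 to compound 3, and both stay within the scatter. On that basis compound 4 is expected to show no step beyond the scatter in this assay, with a 1.0-fold higher number from compound 2 to compound 4 (0.01 log units; within the scatter). The estimate for compound 4 is 80 nM, expected to lie between 40 nM and 160 nM.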

Compound 4, half-maximal inhibitory concentration: 57.4 nM
Beside the measured number, compound 4's estimate is 1.4-fold (0.14 log units) above it; low and high end bracket the measured number.
By their numbers in this assay, from the lowest: compounds 3, 4, 2 and 1 (each within the scatter of the next).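

Taking the side chain away altogether does not move the number beyond the scatter in this assay: with hydrogen on the saturated chain carbon bound to an amide-type nitrogen and a carbonyl carbon, there is a 1.4-fold lower number from compound 2 to compound 4 (0.14 log units; within the scatter), and the two longer side chains give the same picture, with a 1.3-fold higher number from compound 3 to compound 4 (0.11 log units; within the scatter) and a 1.5-fold lower number from compound 1 to compound 4 (0.16 log units; within the scatter). The earlier compounds shown here showed only that one side chain could stand in for another, whereas compound 4 shows that, among the compounds here, no side chain is needed at this position to keep the number within the scatter of the other three. No measurement available here accounts for this lack of separation.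

The compounds shown leave open whether an amine at the end of a longer chain on this carbon would give a step beyond the scatter. They also leave open what a carboxylic acid would do in place of the benzyl ester that all four compounds share.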